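The source may hold more compounds than are shown below. What is called first, only, known or untested is meant among the compounds shown, and "the series" means these compounds.

Measured compounds:
compound 1 `CN1CCC(OC(=O)c2ccc(C#N)cc2)CC1` — 1.65
compound 2 `Cc1ccc(C)c(C(=O)OC2CCN(C)CC2)c1` — 1.36
compound 3 `CN1CCC(OC(=O)c2ccc(Cl)c(Cl)c2)CC1` — 1.08

The three compounds above were tested in a functional assay on the whole organism with Mus musculus as the target; on this read-out higher numbers stand for higher potency (the scale is a negative logarithm) and lower numbers for lower potency. Compound 1 gives the highest of the three numbers. Compound 2 lies close to it, within the usual scatter of repeated measurements, so the two cannot be ordered. Compound 3 sits further off, beyond the scatter, so compound 1 does stand above compound 3 on this read-out.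

The next compound, compound 4 `CN1CCC(OC(=O)c2ccc(F)cc2)CC1`, has not yet been measured in this assay. It differs from compound 1 in one place: fluoro in place of cyano on an aromatic carbon. Both substituents sit on an aromatic carbon of a six-membered aromatic ring of carbon only, para to a large group, and the rest of the molecule is kept.

Going by the values given here, no step between two measured compounds exposes this particular exchange, so the expectation rests on the spread of the three numbers alone. The shift from compound 1 to compound 4 is expected to be small and downward, a number 0.30 log units lower from compound 1 to compound 4 (within the scatter), close to the edge of the scatter. Compound 4 is therefore estimated at 1.35, with a range from 0.9 to 1.8.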

Compound 4, logarithm of the reciprocal of the active concentration, log(1/C): 1.38
The estimate for compound 4 lay 0.03 log units below the measured number, within the range that was stated.
By their numbers in this assay, from the lowest: compounds 3, 2, 4 and 1 (each within the scatter of the next, the first and the last beyond it).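

Fluoro in place of cyano, on an aromatic carbon para to a large group, is the first single exchange that can be read in this assay and it gives a number 0.27 log units lower from compound 1 to compound 4 (within the scatter) with the rest of the molecule kept. At this place, then, cyano, with its two heavy atoms and one hydrogen-bond acceptor, can give way to fluoro, with one heavy atom and no hydrogen-bond acceptor, without a shift that rises above the scatter. Nothing available explains this small step or says what the two groups contribute to the read-out.

As far as these compounds go, whether an amine, a carboxylic acid or a longer chain at this place would move the number beyond the scatter remains open. So does whether fluoro in place of cyano would give a similar step on a different core.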